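The source may hold more compounds than are shown below. What is called first, only, known or untested is meant among the compounds shown, and "the series" means these compounds.

Working notes on the series. Compound 1 `C/C(=C\CC/C(C)=C/CC[C@@H]1[C@@]2(C)CCC(=O)C(C)(C)[C@H]2CC[C@@]1(C)O)CC/C=C(\C)C(=O)OCc1cn(-c2ccccc2C)nn1`, compound 2 `C/C(=C\CC/C(C)=C/CC[C@@H]1[C@@]2(C)CCC(=O)C(C)(C)[C@H]2CC[C@@]1(C)O)CC/C=C(\C)C(=O)OCc1cn(C[C@@H]2O[C@H](n3ccc(=O)[nH]c3=O)[C@H]3OC(C)(C)O[C@H]32)nn1` and compound 3 `C/C(=C\CC/C(C)=C/CC[C@@H]1[C@@]2(C)CCC(=O)C(C)(C)[C@H]2CC[C@@]1(C)O)CC/C=C(\C)C(=O)OCc1cn(-c2ccc([N+](=O)[O-])cc2)nn1` share one core and were all run in a functional assay on DU-145 cells (Homo sapiens) for antiproliferative activity, read by MTT assay, with a stated time of 48 h; a higher number here means a weaker inhibitor, a lower number a stronger inhibitor. Compound 1 reaches only the limit of the assay, giving > 150000 nM in this assay. Compound 2 likewise returns only a limit, > 150000 nM. Compound 3 also stops at the limit, with > 150000 nM. Compound 3 therefore stands at the limit together with the two other measured values, and nothing in the numbers places it relative to them. Within the data shown here, the single one-point step measured so far, a step that the two limits leave unreadable from compound 1 to compound 3, cannot be read in size because both of its ends sit at the limit of > 150000 nM in this assay, at which 3 of the 3 values shown sit.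

Compound 4 `C/C(=C\CC/C(C)=C/CC[C@@H]1[C@@]2(C)CCC(=O)C(C)(C)[C@H]2CC[C@@]1(C)O)CC/C=C(\C)C(=O)OCc1cn(-c2ccc(Br)cc2)nn1` is the next member. It differs from compound 3 in one place: bromo in place of nitro on an aromatic carbon. Among the measured compounds shown here, no measured step bears directly on this change, and the one step in hand, itself a swap of one aryl group for another, is unreadable. With every measured value at the limit, no direction beyond the scatter can be expected; the most probable outcome is that compound 4 also returns only a limit. The expected step is a number no higher from compound 3 to compound 4 (the limit leaves the size open). For compound 4 the estimate in this assay is 150000 nM, between 60000 nM and 300000 nM.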

Compound 4, half-maximal inhibitory concentration: > 150000 nM
Compound 4 ended at the assay's limit (the forecaster's own chance of this, stated with the estimate: 80%); the middle value lies on the limit itself.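

In this assay the steps from compound 3 to compound 4 and from compound 1 to compound 4 cannot be read, because both ends of each step sit at a limit: the limit of > 150000 nM in this assay, at which 4 of the 4 values shown sit. The compounds shown leave open how the groups carried on the shared core rank against one another, as no value short of the limit is in hand.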